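Working notes: trifluoromethyl in place of methyl on compound 2

A few compounds are considered here, and "the series" means these few. Any claim that something is new, unique, unknown or untested is made for them only; others in the source may bear on it.

Measured in an ADME assay on microsomes from liver (Homo sapiens) for metabolic stability; a higher number here means that the compound lasts longer, a lower number that the compound disappears faster:
- compound 1 (`CC#C[C@@H](Cc1nnn[nH]1)c1ccc(OCc2ccc3scc(-c4ccc(OCCCS(C)(=O)=O)cc4C)c3c2)cc1`): 1.28 h
- compound 2 (`CC#C[C@@H](Cc1nnn[nH]1)c1ccc(OCc2ccc3sc(C)c(-c4ccc(OCCOC)cc4C)c3c2)cc1`): 1.48 h
- compound 3 (`CC#C[C@@H](Cc1nnn[nH]1)c1ccc(OCc2ccc3sc(C#N)c(-c4ccccc4C)c3c2)cc1`): 0.0333 h

Compound 2 stands at the top of these three numbers, but only together with compound 1, as the two lie within the scatter of each other. Compound 3 lies far lower, well beyond the scatter from compound 2.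

Compound 4 (`CC#C[C@@H](Cc1nnn[nH]1)c1ccc(OCc2ccc3sc(C(F)(F)F)c(-c4ccc(OCCOC)cc4C)c3c2)cc1`) is compound 2 with trifluoromethyl in place of methyl on an aromatic carbon, next to the ring sulfur (trifluoromethyl in place of methyl on an aromatic carbon). For the measured compounds named here, no measured pair isolates a change on this carbon. Compound 3 (0.0333 h) carries a nitrile there but also differs from compound 2 elsewhere, so its value cannot be read as a step and serves only as a reason to keep the low side of the range wide.

In this assay a small fall is expected, with nothing beyond the scatter as the likeliest outcome. The estimated step (a 1.5-fold lower number from compound 2 to compound 4 (0.17 log units; within the scatter)) starts from the value of compound 2 (1.48 h). For compound 4 the expected value is 1 h, with an estimated range from 0.3 h to 3 h.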

Compound 4, half-life: > 3 h
Compound 4: only a limit was reported; the forecaster's own chance of this, stated with the estimate: 5%; middle value at least 3.0-fold (0.47 log units) from the limit.
By their numbers in this assay, from the lowest: compound 3; then compounds 1 and 2 (each within the scatter of the next). At a limit, above all of these: compound 4.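

For the compounds shown here, the change from methyl to trifluoromethyl on this aromatic carbon, next to the ring sulfur, gives the first step that can be read at this position in this assay: an at least 2.0-fold higher number from compound 2 to compound 4 (0.30 log units; that floor lies within the scatter). Going by these compounds alone, compounds 1 and 3 carry other arrangements on this carbon but also differ from compound 2 elsewhere, so only this pair shows that the exchange on the otherwise unchanged compound 2 brings no fall in half-life. The reading for compound 4 is a limit and not a number, so the step has a floor but no measured size, and that floor does not by itself separate the pair beyond the scatter: the limit of > 3 h in this assay, at which 1 of the 4 values shown sits.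

From the compounds shown here alone, how far the half-life of compound 4 lies past this limit stays open, as does whether the same exchange gives a similar step when the 4-(2-methoxyethoxy)-2-methylphenyl group is replaced. Going by these compounds, it is also open how a chlorine atom, an ethyl group or a carboxamide on this carbon would read against compound 2.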